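A Sulfonyl Swap and Growth Inhibition in Human Cells

A few compounds are considered here, and "the series" means these few. Any claim that something is new, unique, unknown or untested is made for them only; others in the source may bear on it.

In an ADME assay on HEK-293T cells (Homo sapiens) for inhibition, read by CCK-8 assay, with a stated time of 48 h, tested at 20 uM (a lower number here means less inhibition of growth, a higher number more inhibition of growth at the concentration tested), compound 2 (`Cc1ccc(Cc2nnc(NC(=O)/C(C#N)=C/c3ccccc3OS(=O)(=O)c3ccccc3[N+](=O)[O-])s2)cc1`) gives 6%, the only figure available so far. In this assay compound 1 (`N#C/C(=C\c1ccccc1OS(=O)(=O)c1ccc(F)cc1)C(=O)Nc1nnc(Cc2ccc(F)cc2)s1`) is recorded without a number, only as "not toxic" (no number reported), so compound 2 cannot yet be ranked against any other measured value. Compound 3 (`Cc1ccc(Cc2nnc(NC(=O)/C(C#N)=C/c3ccccc3OS(=O)(=O)c3ccc(F)cc3)s2)cc1`) differs from compound 2 by one change: 4-fluorophenyl in place of 2-nitrophenyl on a sulfonyl sulfur, with 4-fluorophenyl in place of 2-nitrophenyl on a sulfonyl sulfur. Within the data shown here, no measured step shows what such a change does. The expectation therefore rests on compound 2 at 6% and on compound 1, which also has 4-fluorophenyl on a sulfonyl sulfur and is recorded as "not toxic" (no number reported). The expected step of a number 1 percentage points higher from compound 2 to compound 3 (within the scatter) in this assay is none beyond the usual scatter, with no firm direction. The estimate for compound 3 is 7%, within a range of 0% to 18%.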

Compound 3, percent growth inhibition at one concentration: 11%
The estimate for compound 3 lay 4 percentage points below the measured number; the measured number falls inside the stated range.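

In this assay, placing 4-fluorophenyl in place of 2-nitrophenyl on a sulfonyl sulfur gives a number 5 percentage points higher from compound 2 to compound 3 (within the scatter). Among these compounds, this is the first measured step at this place, and it shows that the two groups cannot be told apart here at the concentration tested. No measurement shown here offers an explanation for this result.

Among the compounds shown here, compound 1 stands only as "not toxic" (no number reported), so no step involving it can be read. On these data alone, it remains open whether a different group on the sulfonyl sulfur, such as an aminophenyl ring, a carboxylic acid-bearing phenyl ring or a simple alkyl chain, would give a reading in this assay that stands apart from those of compound 2 and compound 3.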